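Stripping the 4-pentylphenyl group from compound 1

The source may report more compounds than this note shows. Statements on the series, on what has been measured and on what is new or still open speak of the compounds shown alone.

Measured so far:
Compound 1 `CCCCCc1ccc(-c2cn(C[C@H](O)[C@H]3OC(=O)C(OCc4ccccc4)=C3OCc3ccccc3)nn2)cc1` gives 12200 nM in a functional assay on SW-620 cells (Homo sapiens) for antiproliferative activity, read by MTT assay, with a stated time of 72 h; on this read-out lower numbers stand for stronger inhibition and higher numbers for weaker inhibition.
Compound 2 `COc1ccccc1-c1cn(C/C=C2\OC(=O)C(OCc3ccccc3)=C2OCc2ccccc2)nn1` gives > 100000 nM in this assay, which is a limit of the assay and not a number.

Among the measured compounds shown here, compound 1 therefore holds the only real number among the two values shown; the other value is a limit, as the limit of > 100000 nM in this assay, at which 1 of the 2 values shown sits, makes clear. Compound 3 `O=C1O[C@H]([C@@H](O)Cn2ccnn2)C(OCc2ccccc2)=C1OCc1ccccc1` differs from compound 1 by hydrogen in place of 4-pentylphenyl on an aromatic carbon. For the measured compounds named here, no two measured compounds differ in a single place, so no measured step tells how large a shift such a change brings, and the size of the expected move rests on the structural change alone. The step of a 3.7-fold higher number from compound 1 to compound 3 (0.57 log units; beyond the scatter) is expected to be a loss of potency that lies beyond the usual scatter. For compound 3 the estimate in this assay is 45000 nM, within a range from 15000 nM to 150000 nM, with a real chance that only a limit is reported.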

Compound 3, half-maximal inhibitory concentration: > 100000 nM
Compound 3: only a limit was reported; the forecaster's own chance of this, stated with the estimate: 35%; middle value at least 2.2-fold (0.34 log units) away from the limit.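

Among the compounds shown here, replacing 4-pentylphenyl with hydrogen on this aromatic carbon of the five-membered aromatic ring with 3 nitrogen gives an at least 8.1-fold higher number from compound 1 to compound 3 (0.91 log units; beyond the scatter) in this assay, the first measured step at this position, and it shows that the measurable activity of compound 1 does not survive the loss of this group. The value of compound 3, > 100000 nM, is a limit of the assay and not a number. With compound 3, more than one of the compounds shown now sits at this limit: the limit of > 100000 nM in this assay, at which 2 of the 3 values shown sit.

The compounds shown leave open how much of the 4-pentylphenyl group is needed, for instance whether a plain phenyl ring would keep the activity of compound 1. On these data alone, it also remains open whether a longer chain, an amine or a carboxylic acid in place of the pentyl chain would strengthen or weaken it.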